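The source may hold more compounds than are shown below. What is called first, only, known or untested is meant among the compounds shown, and "the series" means these compounds.

Measured in a functional assay on MOLT-4 cells (Homo sapiens) for antiproliferative activity, with a stated time of 48 h (on this read-out higher numbers stand for weaker inhibition and lower numbers for stronger inhibition), so far:
- compound 1 (`C=C(Br)C(=O)Nc1ccc(/C=C/C(=O)c2ccccc2)cc1`) (3100 nM)
- compound 2 (`C=C(Br)C(=O)Nc1ccc(/C=C/C(=O)c2ccc(Br)cc2)cc1`) (680 nM)
- compound 3 (`C=C(Br)C(=O)Nc1ccc(/C=C/C(=O)c2ccc(OC)cc2)cc1`) (1300 nM)

Compound 3 is not separated from the bromo member of the set (a 1.9-fold higher number from compound 2 to compound 3 (0.28 log units; within the scatter)), but its number is lower than that of the member carrying hydrogen at that aromatic carbon (a 2.4-fold lower number from compound 1 to compound 3 (0.38 log units; beyond the scatter)).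

The next change leads to compound 4 (`C=C(Br)C(=O)Nc1ccc(/C=C/C(=O)c2cccs2)cc1`), and it is thiophen-2-yl in place of 4-methoxyphenyl on a carbonyl carbon as a whole-group swap. Within the data shown here, no measured step replaces this group outright, so the evidence is indirect. The two steps that add a group on an aromatic carbon are both modest (a 4.6-fold lower number from compound 1 to compound 2 (0.66 log units; beyond the scatter)) and (a 2.4-fold lower number from compound 1 to compound 3 (0.38 log units; beyond the scatter)). Compound 4 carries no added group on its ring, as is also true of compound 1 (3100 nM), so part of the methoxy step may be given back.

The expected change is small and upward (a 1.2-fold higher number from compound 3 to compound 4 (0.09 log units; within the scatter)), and it is not expected to pass the scatter. For compound 4 the estimated value is 1600 nM, with an expected range from 600 nM to 4000 nM in this assay as the read-out.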

Compound 4, half-maximal inhibitory concentration: 550 nM
Compound 4: the middle estimate sits 2.9-fold (0.46 log units) above what was measured; the whole stated range lies above it.
By their numbers in this assay, from the lowest: compounds 4, 2 and 3 (each within the scatter of the next, the first and the last beyond it); then compound 1.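

In this assay, the aryl group on the carbonyl carbon can be exchanged as a whole, not only added to: thiophen-2-yl in place of 4-methoxyphenyl gives (a 2.4-fold lower number from compound 3 to compound 4 (0.37 log units; beyond the scatter)), and in place of phenyl gives the largest step seen so far in the series (a 5.6-fold lower number from compound 1 to compound 4 (0.75 log units; beyond the scatter)). An added group on a six-membered aromatic ring is therefore not required for a low number here, since the unsubstituted five-membered ring is not separated from the 4-bromophenyl member (a 1.2-fold lower number from compound 2 to compound 4 (0.09 log units; within the scatter)). Nothing available explains why thiophen-2-yl reads this way.

Still open, from the compounds shown here alone, is whether bromo or methoxy on the thiophen-2-yl ring would shift the number as they did on phenyl. Also open, going by these compounds, is how a pyridyl or cyclohexyl group would read on the same carbonyl carbon.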